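Cyano for Methoxy Carried onto a Second Core

The compounds below may be only part of what the source reports. "The series", "measured", "known", "first", "only" and "open" are said of these compounds alone.

The compounds were compared in an assay on frontal cortex for displacement of a labelled ligand from corticotropin-releasing factor receptor 1 (Rattus norvegicus); a higher number here means a weaker inhibitor, a lower number a stronger inhibitor. Compound 1 `CCCCN(CC)c1nc(C)nc2c1NC(=O)CN2c1ccc(OC)cc1C` gives 95 nM in this assay. Compound 3 `CCCCN(CC)c1nc(C)nc2c1NC(=O)CN2c1ccc(C#N)cc1C` carries the change cyano in place of methoxy on an aromatic carbon and gives 573 nM; the step is a 6.0-fold higher number from compound 1 to compound 3 (0.78 log units; beyond the scatter).

Compound 2 `CCCCN(CC)c1nc(C)nc2c1NCCN2c1ccc(OC)cc1C` differs from compound 1 in its core, and the difference between the two cores is not broken down here. In this assay compound 2 gives 11.7 nM, the lowest of the three numbers, with compound 1 and compound 3 both beyond the scatter above it.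

Compound 4 `CCCCN(CC)c1nc(C)nc2c1NCCN2c1ccc(C#N)cc1C` has not yet been measured. It relates to compound 2 as compound 3 relates to compound 1, through the change (cyano in place of methoxy on an aromatic carbon), at a place described in the same words for both pairs. Within the data shown here, because the step of a 6.0-fold higher number from compound 1 to compound 3 (0.78 log units; beyond the scatter) from compound 1 to compound 3 is the only guide, a step of about the same size, a 6.0-fold higher number from compound 2 to compound 4 (0.78 log units; beyond the scatter), is expected from compound 2 to compound 4. Compound 4 is therefore estimated at 70 nM in this assay, expected to fall between 25 nM and 200 nM.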

Compound 4, half-maximal inhibitory concentration: 102 nM
For compound 4 the middle estimate is 1.5-fold (0.16 log units) below the measured one; low and high end bracket the measured number.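

Moving from the 4-methoxy-2-methylphenyl to the 4-cyano-2-methylphenyl group on the second core, this assay gives an 8.7-fold higher number from compound 2 to compound 4 (0.94 log units; beyond the scatter), so the change again gives a higher number, as it did on the first core. Set side by side, the two steps do not differ, and in this series the change carries from one core to the other with its size kept: the same change on two cores in this assay, a 6.0-fold higher number (0.78 log units; beyond the scatter) from compound 1 to compound 3 and an 8.7-fold higher number (0.94 log units; beyond the scatter) from compound 2 to compound 4, 1.4-fold (0.16 log units) apart, within the scatter of two such steps. This rests on a single pair for each core in one assay, so it does not show that the step would hold on any further core, and it says nothing about why the size is kept.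

The compounds shown leave open whether another group in the same place, such as an amine or a carboxylic acid, would also behave alike on both cores. They also leave open whether the step would keep its size if the methyl group on that aromatic ring gave way to a longer chain.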